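Amide variation on the thiophene-nitrile series

This account rests on a few compounds, and the source may have more. Where it says the series, first, only, none or still open, it means among the compounds named here.

Measured compounds:
compound 1 `CCC(=O)Nc1sc2c(c1C#N)CCCC2` — 12000 nM
compound 2 `Cc1cccc(-c2cc(C(C)(C)C)cc(C(C)C)c2CO)c1` — 240 nM

In a functional assay on RKE cells for antagonist activity at Vasoactive intestinal polypeptide receptor 1 (Rattus norvegicus), read by HTRF and cAMP accumulation, with stated times of 10 min and 30 min (on this read-out higher numbers stand for weaker inhibition and lower numbers for stronger inhibition), compound 1 gives 12000 nM, the highest of the two numbers recorded; compound 2, built on a different core, gives 240 nM, and the two values lie well apart. Compound 3 `N#Cc1c(NC(=O)c2ccccc2)sc2c1CCCC2` is not yet measured. It differs from compound 1 by phenyl in place of ethyl on a carbonyl carbon, the phenyl in place of ethyl on a carbonyl carbon. For the measured compounds named here, no measured pair shows this kind of change, so the direction is uncertain; a shift no larger than the usual scatter is expected, a 1.5-fold lower number from compound 1 to compound 3 (0.18 log units; within the scatter). Compound 3 is estimated at 8000 nM, within 2000 nM to 30000 nM.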

Compound 3, half-maximal inhibitory concentration: 15000 nM
Compound 3: middle estimate off by 1.9-fold (0.27 log units), on the low side; measured number inside the range.
By their numbers in this assay, from the lowest: compound 2; then compounds 1 and 3 (each within the scatter of the next).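

Phenyl in place of ethyl on a carbonyl carbon gives a 1.3-fold higher number from compound 1 to compound 3 (0.10 log units; within the scatter) in this assay, the first step read at this position. Replacing ethyl with a six-membered aromatic ring of carbon leaves the number within the scatter, so this single change does not separate the two amides. Going by these compounds, whether a longer chain, a benzyl group or an amine at this carbonyl carbon would shift the number beyond the scatter remains open, as does the effect of a substituent such as methoxy on the phenyl. No measurement shown explains the flat step.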